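Adding a sulfanyl group to compound 2

The source may report more compounds than this note shows. Statements on the series, on what has been measured and on what is new or still open speak of the compounds shown alone.

In an ADME assay on the whole organism (strain Sprague-Dawley) for pharmacokinetics, with Rattus norvegicus as the target, read by HPLC, at a dose of 1 mg/kg by the subcutaneous route (on this read-out higher numbers stand for fast clearance and lower numbers for slow clearance), compound 1 (`O=C(Nc1nc2ccccc2s1)c1ccc(OC(F)F)c(OCC2CC2)c1`) gives 0.0208 mL/min/kg, and compound 2 (`O=C(Nc1ccc2ncsc2c1)c1ccc(OC(F)F)c(OCC2CC2)c1`) gives 0.0103 mL/min/kg. Within the data shown here, compound 2 therefore holds the lower of the two numbers measured so far. Among the measured compounds shown here, the single measured step, a 2.0-fold lower number from compound 1 to compound 2 (0.31 log units; beyond the scatter), comes from 1,3-benzothiazol-6-yl in place of 1,3-benzothiazol-2-yl on an amide-type nitrogen. It is modest, though beyond the usual scatter.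

Compound 3 (`O=C(Nc1ccc2nc(S)sc2c1)c1ccc(OC(F)F)c(OCC2CC2)c1`) keeps the rest of compound 2 but carries sulfanyl in place of hydrogen on an aromatic carbon, next to the ring nitrogen and next to the ring sulfur: sulfanyl in place of hydrogen on an aromatic carbon. For the measured compounds named here, no measured compound carries a group at this carbon, so the data offer no direct precedent and no direction for the change. The modest step of a 2.0-fold lower number from compound 1 to compound 2 (0.31 log units; beyond the scatter) is the only indication of size, and it comes from a different kind of change. A step beyond the scatter is therefore not expected in this assay, though the uncertainty is wide. The estimated step is a 1.2-fold higher number from compound 2 to compound 3 (0.07 log units; within the scatter). Compound 3 is expected at 0.012 mL/min/kg, with an estimated range of 0.005 mL/min/kg to 0.03 mL/min/kg.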

Compound 3, clearance: 0.016 mL/min/kg
For compound 3 the middle estimate is 1.3-fold (0.12 log units) below the measured one; measured number inside the range.
By their numbers in this assay, from the lowest: compounds 2, 3 and 1 (each within the scatter of the next, the first and the last beyond it).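

In this assay, among these compounds, the step of a 1.6-fold higher number from compound 2 to compound 3 (0.19 log units; within the scatter) gives the first reading for a group on this carbon, and it lies within the scatter, so sulfanyl in place of hydrogen on an aromatic carbon cannot be told apart from the hydrogen of compound 2 on this read-out. At this place, next to the ring nitrogen and next to the ring sulfur, the change therefore leaves clearance without a clear shift, whereas the change of attachment on the amide-type nitrogen in the earlier step of a 2.0-fold lower number from compound 1 to compound 2 (0.31 log units; beyond the scatter) went beyond the scatter. Nothing in the data gives a reason for the small size of the new step.

As far as these compounds go, whether another group on this carbon, such as an amine, a methyl or a carboxylic acid, would take the number beyond the scatter remains open, as a single substituent cannot set a trend for the position. Also open is whether sulfanyl would give a similar step on the 1,3-benzothiazol-2-yl attachment of compound 1, since the compounds shown carry it only on the 1,3-benzothiazol-6-yl attachment.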